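Changing One Ring Atom Where Both Neighbours Sit at the Limit

The compounds below may be only part of what the source reports. "The series", "measured", "known", "first", "only" and "open" are said of these compounds alone.

Compound 1 `Cc1nnc(SCc2cc(=O)c3cc(Cl)ccc3o2)s1` carries a 5-methyl-1,3,4-thiadiazol-2-yl group on a sulfur whose other neighbour is a saturated chain carbon. In a functional assay on MDA-MB-435S cells (Homo sapiens) for cytotoxicity, read by MTT assay, with a stated time of 72 h (a higher number here means a weaker inhibitor, a lower number a stronger inhibitor), compound 1 gives > 25000 nM, which is a limit of the assay rather than a number. Compound 2 `Cc1nnc(SCc2cc(=O)c3ccccc3o2)s1` differs from it by hydrogen in place of chloro on an aromatic carbon, and in this assay compound 2 gives > 25000 nM, again a limit. The step that the two limits leave unreadable from compound 1 to compound 2 therefore cannot be read, because the limit of > 25000 nM in this assay, at which 2 of the 2 values shown sit, shows both values resting there. Compound 3 `Cc1nnc(SCc2cc(=O)c3cc(Cl)ccc3o2)o1` is not yet measured; it differs from compound 1 by 5-methyl-1,3,4-oxadiazol-2-yl in place of 5-methyl-1,3,4-thiadiazol-2-yl on a sulfur. For the measured compounds named here, no measured step speaks to this change, so the expectation for compound 3 is that this assay again returns a limit, estimated at 30000 nM within 8000 nM to 120000 nM. The expected step that the limit leaves unreadable from compound 1 to compound 3 is thus no readable change.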

Compound 3, half-maximal inhibitory concentration: > 25000 nM
Compound 3 gave a limit, no number; the forecaster's own chance of this, stated with the estimate: 80%; the middle value lies beyond the limit too.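

The step between compound 1 and compound 3 cannot be read, because both compounds give a limit of the assay rather than a number: the limit of > 25000 nM in this assay, at which 3 of the 3 values shown sit.

The compounds shown leave open whether any change to the shared core gives a readable value in this assay.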